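A Fused Ring Returns Where an Aryl Group Had Worked

The source may hold more compounds than are shown below. What is called first, only, known or untested is meant among the compounds shown, and "the series" means these compounds.

Among the compounds with values here, compound 3 `CC(=O)c1ccc(OCC(=O)Nc2cccc(NC(=O)c3ccc(N(C)C)cc3)c2)cc1F` gives 445 nM in an assay on isolated protein for inhibition of Rho-associated protein kinase 1 (Homo sapiens), read by scintillation counting, radiometric assay and 33P incorporation, with a stated time of 40 min, in the presence of a further agent that is not named here (a higher number here means a weaker inhibitor, a lower number a stronger inhibitor), and among the three compounds measured so far it is the only one with a real number. Compound 1 `CN(C)c1ccc(C(=O)Nc2cccc(NC(=O)COc3ccc4c(c3)CCC(=O)N4)c2)cc1` reaches only the limit > 10000 nM in this assay. Compound 2 `COc1cccc(OCC(=O)Nc2cccc(NC(=O)c3ccc(N(C)C)cc3)c2)c1` likewise reaches only the limit > 10000 nM in this assay. Both of those sit at the limit of > 10000 nM in this assay, at which 2 of the 3 values shown sit.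

Compound 4 `CN(C)c1ccc(C(=O)Nc2cccc(NC(=O)COc3ccc4c(c3)OCCC4=O)c2)cc1` differs from compound 3 in one place: a group of 11 heavy atoms (9 carbon, 2 oxygen; one six-membered non-aromatic ring with 1 hetero atom, one six-membered aromatic ring of carbon only) in place of a group of 10 heavy atoms (8 carbon, 1 oxygen, 1 fluorine; one six-membered aromatic ring of carbon only), on an oxygen on a saturated carbon. Within the data shown here, two measured steps bear on this. Replacing a bicyclic group with a six-membered non-aromatic ring by the 4-acetyl-3-fluorophenyl group gave an at least 22-fold lower number from compound 1 to compound 3 (1.35 log units; beyond the scatter), and replacing 3-methoxyphenyl by the same group gave an at least 22-fold lower number from compound 2 to compound 3 (1.35 log units; beyond the scatter). The change to compound 4 runs the first of these backwards, bringing in a bicyclic group that again holds a six-membered non-aromatic ring with one hetero atom. A large rise in the number is therefore expected, an 18-fold higher number from compound 3 to compound 4 (1.25 log units; beyond the scatter), and compound 4 is estimated at 8000 nM in this assay, within a range of 2000 nM to 30000 nM, with a real chance that only a limit is reported.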

Compound 4, half-maximal inhibitory concentration: 144 nM
Compound 4: middle estimate off by 56-fold (1.74 log units), on the high side, outside the stated range (below it).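

Within the data shown here, the fused two-ring group on this oxygen is not a drawback in itself: in this assay it gives a 3.1-fold lower number from compound 3 to compound 4 (0.49 log units; beyond the scatter), so 4-acetyl-3-fluorophenyl is not the only group here that yields a real number. What counts is which fused group is present, since two groups of equal heavy-atom count and the same ring types, one with two oxygens and the other with one nitrogen and one oxygen, give an at least 69-fold lower number from compound 1 to compound 4 (1.84 log units; beyond the scatter). The step from 3-methoxyphenyl is an at least 69-fold lower number from compound 2 to compound 4 (1.84 log units; beyond the scatter), and like the step before it, this one starts from a limit rather than a number, so its true size stays unknown: the limit of > 10000 nM in this assay, at which 2 of the 4 values shown sit.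

Which atoms of the group in compound 4 account for the gain remains open. So does whether an amine or a carboxylic acid on that group would keep the number this low.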